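Removing a chlorine from a fatty acid receptor agonist

This account rests on a few compounds, and the source may have more. Where it says the series, first, only, none or still open, it means among the compounds named here.

Measured compounds:
Compound 1, `O=C(O)CCc1ccc(OCc2ncc(-c3ccccc3)o2)cc1`: 1600 nM
Compound 2, `O=C(O)CCc1ccc(OCc2ncc(-c3cccc(Cl)c3)o2)cc1`: 47500 nM
Compound 3, `O=C(O)CCc1ccc(OCc2nc(-c3ccccc3Cl)no2)cc1`: 1200 nM

All three compounds were tested in a functional assay on CHO cells for agonist activity at Free fatty acid receptor 1 (Homo sapiens), read by FLIPR and calcium flux, in the presence of a further agent that is not named here; a lower number here means that less compound is needed, a higher number that more compound is needed for the effect. Compound 2 differs from compound 1 in one place: hydrogen in place of chloro on an aromatic carbon. This change brought a 30-fold lower number from compound 2 to compound 1 (1.47 log units; beyond the scatter). Compound 3 carries a different core; how the core of compound 3 differs from the core of compound 2 is not broken down here. In this assay compound 3 gives 1200 nM, and its value and that of compound 1 lie within the usual scatter of each other, so the two cannot be ranked.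

Compound 4, `O=C(O)CCc1ccc(OCc2nc(-c3ccccc3)no2)cc1`, has not been measured. It differs from compound 3 by hydrogen in place of chloro on an aromatic carbon. Going by the values given here, this is the same kind of change as the one from compound 2 to compound 1, but not the same: there the chloro sat meta to a large group, here it sits ortho to a large group, and the core is different as well.

The step from compound 3 to compound 4 is expected to be a 1.2-fold lower number from compound 3 to compound 4 (0.08 log units; within the scatter), smaller than the earlier one, because compound 3 already gives 1200 nM, close to compound 1. In this assay compound 4 is estimated at 1000 nM, with a plausible range from 300 nM to 4000 nM.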

Compound 4, half-maximal effective concentration: 1130 nM
Compound 4: middle estimate off by 1.1-fold (0.05 log units), on the low side, within the range that was stated.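

In this assay, removing the chlorine does not have the same result on the two cores: the same change on two cores in this assay, a 30-fold lower number (1.47 log units; beyond the scatter) from compound 2 to compound 1 and a 1.1-fold lower number (0.03 log units; within the scatter) from compound 3 to compound 4, 28-fold (1.45 log units) apart, beyond the scatter of two such steps

On the core shared by the second pair, the swap from 2-chlorophenyl to phenyl brings a 1.1-fold lower number from compound 3 to compound 4 (0.03 log units; within the scatter), so those two compounds cannot be ranked, whereas the chlorine made a large difference in the first pair. What this does not show is the reason for the gap: the two pairs differ in their core and also in where the chlorine stands on the phenyl ring, and with one pair for each core, these compounds cannot tell which of those two differences matters, or whether both do.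

Going by these compounds, it remains open whether a chlorine placed identically on both cores would give two matching steps or would still give different ones. Also open, on these data alone, is how a fluoro or a methoxy group on the phenyl ring would behave on either core, and what a longer chain leading to the carboxylic acid would do to the number.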